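Fluoro to methoxy on compound 3

This account rests on a few compounds, and the source may have more. Where it says the series, first, only, none or still open, it means among the compounds named here.

compound 1 `CN1CCN(c2ccc(-c3cc4c(N5CCN(S(=O)(=O)C6CC6)CC5)ncnc4s3)cc2)CC1`: 11500 nM
compound 2 `CN1CCN(c2ccc(-c3cc4c(N5CCN(C(=O)Nc6ccc(OC(F)(F)F)cc6)CC5)ncnc4s3)cc2)CC1`: 4600 nM
compound 3 `CN1CCN(c2ccc(-c3cc4c(N5CCN(C(=O)Nc6ccccc6F)CC5)ncnc4s3)cc2)CC1`: 10300 nM

All three numbers come from a functional assay on MDA-MB-231 cells (Homo sapiens) for antiproliferative activity, read by MTT assay, with a stated time of 48 h; on this read-out higher numbers stand for weaker inhibition and lower numbers for stronger inhibition. Compound 3, at 10300 nM, sits with compound 1 at the high end of this small set, and the data show a 1.1-fold lower number from compound 1 to compound 3 (0.05 log units; within the scatter). The next molecule, compound 4 `COc1ccccc1NC(=O)N1CCN(c2ncnc3sc(-c4ccc(N5CCN(C)CC5)cc4)cc23)CC1`, makes one small edit: methoxy in place of fluoro on an aromatic carbon, ortho to a large group (methoxy in place of fluoro on an aromatic carbon).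

Among the compounds with values here, no measured pair makes this exact swap. The closest guide is compound 2, which carries a different group on the same aromatic ring, with a 2.2-fold higher number from compound 2 to compound 3 (0.35 log units; beyond the scatter). Even that change of substituent gave only a modest step, and three compounds are thin evidence. A step beyond the scatter is therefore not expected in this assay. The estimated step is a 1.2-fold lower number from compound 3 to compound 4 (0.08 log units; within the scatter).

For compound 4 the expected value is 8500 nM, with an estimated range of 3800 nM to 17000 nM.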

Compound 4, half-maximal inhibitory concentration: 23200 nM
Beside the measured number, compound 4's estimate is 2.7-fold (0.44 log units) below it, and the stated range ends below it.
By their numbers in this assay, from the lowest: compound 2; then compounds 3, 1 and 4 (each within the scatter of the next, the first and the last beyond it).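

In this assay, methoxy in place of fluoro on this aromatic carbon, ortho to a large group, gives a 2.3-fold higher number from compound 3 to compound 4 (0.35 log units; beyond the scatter) and so moves toward weaker inhibition, showing that this position responds to a small edit. Within the data shown here, the same compound also widens the spread of the series: 2-methoxyphenyl in place of 4-(trifluoromethoxy)phenyl gives a 5.0-fold higher number from compound 2 to compound 4 (0.70 log units; beyond the scatter) as the largest step so far, whereas (2-methoxyphenyl)carbamoyl in place of cyclopropylsulfonyl gives a 2.0-fold higher number from compound 1 to compound 4 (0.30 log units; within the scatter) and stays within the usual scatter. No measurement shown here explains the direction of the methoxy step.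

The compounds shown leave open what a hydroxyl group or an amine on this same aromatic carbon would do. They also leave open whether a longer chain such as ethoxy would push the number further in the same direction.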